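Working notes: 4-chlorobenzyl to 4-methylbenzyl

The source may hold more compounds than are shown below. What is called first, only, known or untested is meant among the compounds shown, and "the series" means these compounds.

Compound 1 `Cc1ccc(S(=O)(=O)Oc2ccccc2/C=C(\C#N)C(=O)Nc2nnc(C)s2)cc1`: 35%
Compound 2 `COc1ccc(Cc2nnc(NC(=O)/C(C#N)=C/c3ccccc3OS(=O)(=O)c3ccc(C)cc3)s2)cc1`: 21%
Compound 3 `Cc1ccc(S(=O)(=O)Oc2ccccc2/C=C(\C#N)C(=O)Nc2nnc(Cc3ccc(Cl)cc3)s2)cc1`: 20%

In an ADME assay on HEK-293T cells (Homo sapiens) for inhibition, read by CCK-8 assay, with a stated time of 48 h, tested at 20 uM (a lower number here means less inhibition of growth, a higher number more inhibition of growth at the concentration tested), compound 3 gives 20%, which cannot be told apart from compound 2 at 21%: the record shows a number 1 percentage points lower from compound 2 to compound 3 (within the scatter). Compound 1 stands clearly higher, with a number 15 percentage points lower from compound 1 to compound 3 (beyond the scatter).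

The next structure is compound 4 `Cc1ccc(Cc2nnc(NC(=O)/C(C#N)=C/c3ccccc3OS(=O)(=O)c3ccc(C)cc3)s2)cc1`, still unmeasured. The change is methyl in place of chloro on an aromatic carbon, para to a large group, turning 4-chlorobenzyl into 4-methylbenzyl.

Among the measured compounds shown here, the closest precedent is the swap at this same place, a number 1 percentage points lower from compound 2 to compound 3 (within the scatter), chloro in place of methoxy. For the measured compounds named here, it is the only measured exchange of this substituent, so the evidence is thin. The larger steps, a number 14 percentage points lower from compound 1 to compound 2 (beyond the scatter) and a number 15 percentage points lower from compound 1 to compound 3 (beyond the scatter), both modest, come from placing a substituted phenyl on the saturated chain carbon. Compound 4 keeps a substituted phenyl there, so these steps do not carry over to the present change. No step beyond the scatter is therefore expected in this assay. The expected outcome is a number 1 percentage points higher from compound 3 to compound 4 (within the scatter). Compound 4 is estimated at 21%, with an expected range of 11% to 32%.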

Compound 4, percent growth inhibition at one concentration: 22%
Compound 4: the middle estimate sits 1 percentage points below what was measured; the range from low to high includes it.
By their numbers in this assay, from the lowest: compounds 3, 2 and 4 (each within the scatter of the next); then compound 1.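

In this assay, methyl on the aromatic carbon para to a large group cannot be told apart from chloro (a number 2 percentage points higher from compound 3 to compound 4 (within the scatter)) or from methoxy (a number 1 percentage points higher from compound 2 to compound 4 (within the scatter)), so all three substituents at this place now fall within the scatter of one another. A third substituted phenyl on the saturated chain carbon again stands clear of compound 1 (a number 13 percentage points lower from compound 1 to compound 4 (beyond the scatter)), so across these compounds the separation from compound 1 goes with the presence of the substituted phenyl, whichever of the three para substituents it carries. No available data give a reason for this flat response at the para place.

The compounds shown leave open whether a group of another kind at this place, such as an amine or a carboxylic acid, would stay within the same narrow band as methyl, chloro and methoxy. They also leave open how a plain phenyl without a para substituent, or a longer chain in place of the 4-methylbenzyl group, would read against compound 1.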